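Swapping methylsulfanyl for cyclopropyl in a weak mitochondrial inhibitor

This account rests on a few compounds, and the source may have more. Where it says the series, first, only, none or still open, it means among the compounds named here.

Measured so far in a toxicity assay on mitochondria from liver (Rattus norvegicus) for inhibition, in the presence of a further agent that is not named here; a higher number here means a weaker inhibitor, a lower number a stronger inhibitor:
compound 1 `Cc1c(C)n(C(=O)c2ccc(O)c(C#N)c2)c2ccccc12`: 3600 nM
compound 2 `CSc1cc(C(=O)N2CCc3ccccc32)cc(C#N)c1O`: 40000 nM

Within the data shown here, only two compounds have been measured so far, and they differ in more than one place. Compound 2 stands at 40000 nM, the higher of the two numbers and so the weaker inhibitor of the pair. Compound 1 sits at 3600 nM, and the gap between the two lies beyond the scatter.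

The next compound, compound 3 `N#Cc1cc(C(=O)N2CCc3ccccc32)cc(C2CC2)c1O`, keeps the rest of compound 2 and carries cyclopropyl in place of methylsulfanyl on an aromatic carbon, ortho to a hydroxy group and meta to a cyano group (cyclopropyl in place of methylsulfanyl on an aromatic carbon). Among the measured compounds shown here, no measured pair shows what this exchange does in this assay, so the only anchor is compound 2 at 40000 nM.

No step beyond the scatter is expected, and any shift should lean slightly toward a stronger inhibitor. The expected step is a 1.3-fold lower number from compound 2 to compound 3 (0.12 log units; within the scatter). For compound 3 the estimated value is 30000 nM, with an expected range from 10000 nM to 90000 nM.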

Compound 3, half-maximal inhibitory concentration: 24000 nM
Estimate against measurement, compound 3: 1.3-fold (0.10 log units) above; the range from low to high includes it.
By their numbers in this assay, from the lowest: compound 1; then compounds 3 and 2 (each within the scatter of the next).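

Among these compounds, the pair of compound 2 and compound 3 is the first to isolate a single change, and in this assay the exchange of methylsulfanyl for cyclopropyl on an aromatic carbon, ortho to a hydroxy group and meta to a cyano group, gives a 1.7-fold lower number from compound 2 to compound 3 (0.22 log units; within the scatter). At this position, then, the sulfur and the hydrogen-bond acceptor counted for methylsulfanyl can give way to a three-membered ring of carbon only with no difference that can be read beyond the scatter, and both compounds remain in the same band of the assay. Nothing at hand bears on why these two groups are so hard to tell apart here.

What the compounds shown leave open is whether this position responds at all in this assay, since a single exchange within the scatter cannot separate a position that tolerates anything from two groups that merely happen to match, and an amine, a carboxylic acid or a longer chain on the same carbon would test that. On these data alone, it also remains open whether the same exchange would read the same way on the core of compound 1, which carries neither group.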